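Trifluoromethyl in place of fluoro on compound 1

A few compounds are considered here, and "the series" means these few. Any claim that something is new, unique, unknown or untested is made for them only; others in the source may bear on it.

In a functional assay on MCF7 cells (Homo sapiens) for antiproliferative activity, read by MTT assay, with a stated time of 48 h (on this read-out lower numbers stand for stronger inhibition and higher numbers for weaker inhibition), compound 1 `COc1ccc(-c2nnc(NC(=O)/C=C/c3ccc(F)cc3)s2)cc1` gives 0.85 ug/mL as its value. In this assay compound 2 `O=C(/C=C/c1ccc(F)cc1)Nc1nnc(-c2ccc(Br)cc2)s1` gives 1.49 ug/mL and compound 3 `Cc1ccc(-c2nnc(NC(=O)/C=C/c3ccc(F)cc3)s2)cc1` gives 1.27 ug/mL in the same test, so compound 1 stands within the scatter of both.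

The change to compound 4 `COc1ccc(-c2nnc(NC(=O)/C=C/c3ccc(C(F)(F)F)cc3)s2)cc1` is trifluoromethyl in place of fluoro on an aromatic carbon with the methoxy group kept. Within the data shown here, no measured step touches the fluoro group, so direct evidence is missing. The steps measured at the methoxy site are a 1.8-fold higher number from compound 1 to compound 2 (0.24 log units; within the scatter) and a 1.5-fold higher number from compound 1 to compound 3 (0.17 log units; within the scatter) and a 1.2-fold lower number from compound 2 to compound 3 (0.07 log units; within the scatter) and all three stay within the scatter. They lie at a different place and offer only indirect guidance. No shift beyond the scatter is therefore expected in this assay and the expected step is a 1.2-fold higher number from compound 1 to compound 4 (0.07 log units; within the scatter) with no firm direction. For compound 4 the estimate is 1 ug/mL with an expected range from 0.4 ug/mL to 2.5 ug/mL as the likely spread.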

Compound 4, half-maximal inhibitory concentration: 0.79 ug/mL
Compound 4: the middle estimate sits 1.3-fold (0.10 log units) above what was measured, within the range that was stated.
By their numbers in this assay, from the lowest: compounds 4, 1, 3 and 2 (each within the scatter of the next).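

Among these compounds, this is the first step at the fluoro position, on an aromatic carbon of a six-membered aromatic ring of carbon only, para to a large group: in this assay the change gives a 1.1-fold lower number from compound 1 to compound 4 (0.03 log units; within the scatter). With the methoxy group kept, trifluoromethyl with 4 heavy atoms stands in for fluoro with 1 heavy atom, and the read-out stays within the scatter, so the second site varied in the series also shows no shift so far. No measurement shown gives a reason for this result.

The compounds shown leave open whether trifluoromethyl would behave the same way with bromo or methyl in place of methoxy. They also leave open whether an amine or a carboxylic acid at this position would move the number beyond the scatter.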